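The source may report more compounds than this note shows. Statements on the series, on what has been measured and on what is new or still open speak of the compounds shown alone.

In a functional assay on T29Kt1 cells (Homo sapiens) for cytotoxicity, read by sulforhodamine B assay, with a stated time of 3 days (on this read-out higher numbers stand for weaker inhibition and lower numbers for stronger inhibition), compound 1 (`OCc1cn(Cc2ccc(Cl)cc2)c2ccccc12`) gives 79 nM and compound 2 (`Cc1ccc(Cn2cc(CO)c3ccccc32)cc1`) gives 150 nM, so the two share the low end of the series. Methyl in place of chloro on an aromatic carbon is a 1.9-fold higher number from compound 1 to compound 2 (0.28 log units; within the scatter). Compound 3 (`OCc1cn(Cc2ccc(Cl)cc2)c2cc(F)ccc12`) gives 1000 nM, which is a 13-fold higher number from compound 1 to compound 3 (1.10 log units; beyond the scatter), for fluoro in place of hydrogen on an aromatic carbon. Compound 4 (`CC(O)c1cn(Cc2ccc(Cl)cc2)c2ccccc12`) carries methyl in place of hydrogen on a saturated chain carbon bound to an aromatic carbon and an oxygen on a saturated carbon, read also as hydroxymethyl to 1-hydroxyethyl. For the measured compounds named here, neither measured step touches this place, so no direct precedent exists, and the large fluoro step shows only that one small change can matter here. A modest rise is weakly expected in this assay, as the estimated 2.5-fold higher number from compound 1 to compound 4 (0.40 log units; beyond the scatter). For compound 4 the estimate is 200 nM, with an expected range of 60 nM to 800 nM.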

Compound 4, half-maximal inhibitory concentration: 19900 nM
The estimate for compound 4 lay 100-fold (2.00 log units) below the measured number; the measured number lies above the stated range.
By their numbers in this assay, from the lowest: compounds 1 and 2 (each within the scatter of the next); then compound 3; then compound 4.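

In this assay, methyl in place of hydrogen on this saturated chain carbon gives the largest step in the series, a 250-fold higher number from compound 1 to compound 4 (2.40 log units; beyond the scatter). A single added carbon at this place thus costs far more than the exchange of chloro for methyl between compound 1 and compound 2, which stays within the scatter, so hydroxymethyl and 1-hydroxyethyl are not interchangeable here. Nothing available bears on the reason for this loss.

Still open, from the compounds shown here alone, is how an ethyl group on this carbon would read. Also open, going by these compounds, is whether an aminomethyl group or a carboxylic acid in place of the hydroxymethyl would stay near compound 1.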